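The source may hold more compounds than are shown below. What is called first, only, known or untested is meant among the compounds shown, and "the series" means these compounds.

Working notes on the series. Two compounds carry numbers in a functional assay on MCF7 cells (Homo sapiens) for cytotoxicity (on this read-out lower numbers stand for an effect already at smaller amounts and higher numbers for an effect only at larger amounts of compound), so far. Compound 1 `COc1cc(Cc2nc3c(N)ncnc3n2CC(C)CCCO)cc(OC)c1OC` and compound 2 `COCCCn1c(Cc2cc(OC)c(OC)c(OC)c2)nc2c(N)nc(F)nc21` share the same core; in this assay compound 1 gives 8770000 nM, while compound 2 gives 72600000 nM. Compound 2 thus stands at the higher of the two numbers, and the gap to compound 1 lies beyond the scatter of repeated runs. Both numbers are far up the scale, so neither compound shows an effect at small amounts.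

The next step goes from compound 2 to compound 3 `COc1cc(Cc2nc3c(N)nc(F)nc3n2CC2CCCO2)cc(OC)c1OC`. The change is oxolan-2-yl in place of 2-methoxyethyl on a saturated chain carbon bound to an aromatic nitrogen: a 2-methoxyethyl group leaves and an oxolan-2-yl group enters, on a saturated chain carbon bound to an aromatic nitrogen. Going by the values given here, no step between measured compounds of this kind is available, so there is nothing in the data to anchor the size of this change. With both measured numbers so high and a change of this size, the expected step of a 1.5-fold lower number from compound 2 to compound 3 (0.16 log units; within the scatter) is small, in no firm direction, and likely within the scatter. Compound 3 is therefore estimated at 50000000 nM in this assay, with a range from 10000000 nM to 200000000 nM.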

Compound 3, half-maximal effective concentration: 147000000 nM
The estimate for compound 3 lay 2.9-fold (0.47 log units) below the measured number, within the range that was stated.
By their numbers in this assay, from the lowest: compound 1; then compound 2; then compound 3.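

In this assay, going by these compounds alone, the exchange of 2-methoxyethyl for oxolan-2-yl, on a saturated chain carbon bound to an aromatic nitrogen, gives a 2.0-fold higher number from compound 2 to compound 3 (0.31 log units; beyond the scatter) and so provides the first reading at this place with only one thing changed. Compound 1 and compound 2 differ in more than one place, so that pair could not isolate a change here; this step shows that replacing the open chain with a five-membered non-aromatic ring, with the hydrogen-bond acceptor count unchanged, moves the number modestly upward and brings no effect at smaller amounts. Nothing at hand accounts for the direction or size of this step.

From the compounds shown here alone, whether any group on this saturated chain carbon can bring the number down remains open, as a single step gives no trend, and an amine, a carboxylic acid or a plain propyl chain could each test how far the number moves with the ether oxygen gone. Also open, going by these compounds, is whether the same exchange gives a step of similar size and direction on the core of compound 1.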